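From 3-nitrophenyl to 4-cyanophenyl on a shared core

A few compounds are considered here, and "the series" means these few. Any claim that something is new, unique, unknown or untested is made for them only; others in the source may bear on it.

Measured so far in a functional assay on HepG2 cells (Homo sapiens) for cytotoxicity, read by MTT assay, with a stated time of 24 h; a higher number here means a weaker inhibitor, a lower number a stronger inhibitor:
- compound 1 `COc1cc(/C=C2\CN(S(=O)(=O)c3ccc(F)cc3)C/C(=C\c3cc(OC)c(OC)c(OC)c3)C2=O)cc(OC)c1OC` gives 4200 nM
- compound 2 `COc1cc(/C=C2\CN(S(=O)(=O)c3ccc(F)cc3)C/C(=C\c3cccc([N+](=O)[O-])c3)C2=O)cc(OC)c1OC` gives 3250 nM

Compound 2 stands within the scatter of compound 1, so the two numbers do not separate these compounds. Compound 3 `COc1cc(/C=C2\CN(S(=O)(=O)c3ccc(F)cc3)C/C(=C\c3ccc(C#N)cc3)C2=O)cc(OC)c1OC`, not yet measured, differs from compound 2 in one place: 4-cyanophenyl in place of 3-nitrophenyl on a double-bonded chain carbon bound to a double-bonded ring carbon. Within the data shown here, only one measured step bears on this place: a 1.3-fold lower number from compound 1 to compound 2 (0.11 log units; within the scatter), with 3-nitrophenyl in place of 3,4,5-trimethoxyphenyl. Among the measured compounds shown here, no compound with 4-cyanophenyl has a number yet, and this single step is thin evidence. No shift beyond the scatter in this assay is therefore expected, in either direction. The expected change is a 1.0-fold higher number from compound 2 to compound 3 (0.01 log units; within the scatter). For compound 3 the estimated value is 3300 nM, with an expected range of 1300 nM to 8000 nM.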

Compound 3, half-maximal inhibitory concentration: 4950 nM
Estimate against measurement, compound 3: 1.5-fold (0.18 log units) below; measured number inside the range.
By their numbers in this assay, from the lowest: compounds 2, 1 and 3 (each within the scatter of the next).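

In this assay, the step of a 1.5-fold higher number from compound 2 to compound 3 (0.18 log units; within the scatter) and the step of a 1.2-fold higher number from compound 1 to compound 3 (0.07 log units; within the scatter) both lie within the scatter, so 4-cyanophenyl does not separate from either earlier group on the double-bonded chain carbon bound to a double-bonded ring carbon. Until now this position rested on a single step between two groups; with three groups, every pair of compounds reads alike. Even exchanging the nitro group and its oxygens for a nitrile with its triple bond leaves the number within the scatter, so none of the three changes here shows this position to matter in this assay.

From the compounds shown here alone, whether an aminophenyl or a carboxyphenyl group at this place would move the number beyond the scatter remains open. No measurement is available that could explain the result or say what the three groups share.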